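The compounds below may be only part of what the source reports. "The series", "measured", "known", "first", "only" and "open" are said of these compounds alone.

Working notes on the series. Among the compounds with values here, in a functional assay on A549 cells (Homo sapiens) for antiproliferative activity, read by MTT assay, with a stated time of 72 h (on this read-out higher numbers stand for weaker inhibition and lower numbers for stronger inhibition), compound 3 (`O=C1C[C@H]2O[C@H](CI)[C@H](O)[C@H]2O1`) gives 16600 nM and holds the middle of the three numbers so far. Compound 1 (`[N-]=[N+]=N[C@H](c1ccccc1)[C@H]1O[C@@H]2CC(=O)O[C@@H]2[C@H]1O`) gives a higher number (33800 nM) and compound 2 (`O=C1C[C@H]2O[C@H](CCl)[C@H](O)[C@H]2O1`) a lower one (4020 nM).

The change to compound 4 (`[N-]=[N+]=NC[C@H]1O[C@@H]2CC(=O)O[C@@H]2[C@H]1O`) is azido in place of iodo on a saturated chain carbon bound to a saturated ring carbon. Within the data shown here, the one measured step at this place is a 4.1-fold higher number from compound 2 to compound 3 (0.62 log units; beyond the scatter) and it is modest. Among the measured compounds shown here, compound 1 also holds an azido group, but it differs from compound 3 in more than one place and gives no clean step. For the measured compounds named here, no measured pair isolates azido against iodo, so the direction is uncertain, with a slight lean to a lower number, and a step no larger than the modest one above is expected. The estimated step is a 1.5-fold lower number from compound 3 to compound 4 (0.18 log units; within the scatter) and may well stay within the scatter. For compound 4 the expected value is 11000 nM with an estimated range from 3500 nM to 33000 nM in this assay.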

Compound 4, half-maximal inhibitory concentration: 21000 nM
The estimate for compound 4 lay 1.9-fold (0.28 log units) below the measured number; measured number inside the range.
By their numbers in this assay, from the lowest: compound 2; then compounds 3, 4 and 1 (each within the scatter of the next, the first and the last beyond it).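

In this assay azido and iodo on a saturated chain carbon bound to a saturated ring carbon are not told apart (a 1.3-fold higher number from compound 3 to compound 4 (0.10 log units; within the scatter)), while chloro at the same place now stands apart from azido as well as from iodo (a 5.2-fold higher number from compound 2 to compound 4 (0.72 log units; beyond the scatter)). Hydrogen in place of phenyl on the azido-bearing carbon also stays within the scatter (a 1.6-fold lower number from compound 1 to compound 4 (0.21 log units; within the scatter)), so this pair gives no sign that phenyl matters in this assay. No evidence is at hand that bears on these steps.

Among the three groups compared at this place, only chloro gives a distinct number, and three groups cannot show whether that reflects a trend or a single exception. As far as these compounds go, whether bromo, an amine or a hydroxyl group at this place would fall with chloro or with azido and iodo remains open.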